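Ethyl for Methyl on a Second Core: Expected Inactivity

This account rests on a few compounds, and the source may have more. Where it says the series, first, only, none or still open, it means among the compounds named here.

Compound 1 `C/C=C1/[C@H](O[C@@H]2O[C@H](CO)[C@@H](O)[C@H](O)[C@H]2O)OC=C(C(=O)OC)[C@H]1CC(=O)OC` carries a methyl ester on its side chain. Compound 2 `C/C=C1/[C@H](O[C@@H]2O[C@H](CO)[C@@H](O)[C@H](O)[C@H]2O)OC=C(C(=O)OC)[C@H]1CC(=O)OCC` differs from it by methyl in place of hydrogen on a saturated chain carbon bound to an oxygen next to a carbonyl group. In a functional assay on SK-BR-3 cells (Homo sapiens) for antiproliferative activity, read by MTT assay, with a stated time of 72 h (on this read-out lower numbers stand for stronger inhibition and higher numbers for weaker inhibition), compound 1 gives > 15000 nM, which is a limit of the assay rather than a number. In this assay compound 2 gives > 15000 nM, again a limit. The step that the two limits leave unreadable from compound 1 to compound 2 therefore cannot be sized. Compound 3 `C/C=C1/[C@H](O[C@@H]2O[C@H](COC(C)=O)[C@@H](OC(C)=O)[C@H](OC(C)=O)[C@H]2OC(C)=O)OC=C(C(=O)OC)[C@H]1CC(=O)OC` has a different core; the difference between its core and that of compound 1 is not broken down here. In this assay compound 3 gives > 15000 nM, once more a limit. Compound 4 `C/C=C1/[C@H](O[C@@H]2O[C@H](COC(C)=O)[C@@H](OC(C)=O)[C@H](OC(C)=O)[C@H]2OC(C)=O)OC=C(C(=O)OC)[C@H]1CC(=O)OCC`, not yet measured, differs from compound 3 by methyl in place of hydrogen on a saturated chain carbon bound to an oxygen next to a carbonyl group, the same change at the same place as before. Because all three measured values rest on the limit of > 15000 nM in this assay, at which 3 of the 3 values shown sit, and the earlier step gave no readable size, the step that the limit leaves unreadable from compound 3 to compound 4 is expected to be small and to leave compound 4 at the limit. Compound 4 is estimated at 25000 nM, between 10000 nM and 80000 nM.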

Compound 4, half-maximal inhibitory concentration: > 15000 nM
Compound 4: a limit, no number (the forecaster's own chance of this, stated with the estimate: 85%); the middle value lies beyond the limit too.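

In this assay compound 4 gives > 15000 nM, which is a limit of the assay and not a number, so the step from compound 3 to compound 4 cannot be read. The compounds shown leave open whether methyl to ethyl changes activity at all, because every result rests on the same limit: the limit of > 15000 nM in this assay, at which 4 of the 4 values shown sit.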